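Chlorine position on the benzylsulfanyl group of the shared core

A few compounds are considered here, and "the series" means these few. Any claim that something is new, unique, unknown or untested is made for them only; others in the source may bear on it.

Working notes on a small set built on the shared core of compound 1 `CC1=C(C(=O)Nc2ccc(Br)cc2)C(c2ccc(Cl)cc2Cl)N=C(SCc2ccccc2Cl)N1`; compound 2 `CC1=C(C(=O)Nc2ccc(Br)cc2)C(c2ccc(Cl)cc2Cl)N=C(SCc2cccc(Cl)c2)N1` carries 3-chlorophenyl in place of 2-chlorophenyl on a saturated chain carbon bound to a sulfur. In a functional assay on the whole organism (artery, strain albino) with Rattus norvegicus as the target, with a stated time of 360 min, at a dose of 10 mg/kg by the oral route (on this read-out lower numbers stand for less inhibition and higher numbers for more inhibition at the one dose given (going by the name of the read-out)), compound 1 gives 38.1%, and compound 2 gives 20.6%. Within the data shown here, of the two numbers compound 2 stands lowest, and the only measured step in the set is a number 17.5 percentage points lower from compound 1 to compound 2 (beyond the scatter).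

Compound 3 `CC1=C(C(=O)Nc2ccc(Br)cc2)C(c2ccc(Cl)cc2Cl)N=C(SCc2ccc(Cl)cc2)N1` has not been measured. Its difference from compound 2 is 4-chlorophenyl in place of 3-chlorophenyl on a saturated chain carbon bound to a sulfur. Among the measured compounds shown here, the one measured step that bears on this change is a number 17.5 percentage points lower from compound 1 to compound 2 (beyond the scatter), which also exchanged one chlorophenyl for another on the same saturated chain carbon bound to a sulfur and gave a modest drop. Whether a further exchange continues that drop or reverses it cannot be read from one step, so the expected step is a number 4.4 percentage points higher from compound 2 to compound 3 (within the scatter), within the scatter and with wide uncertainty. Compound 3 is therefore estimated to give about 25% in this assay, within a range from 5% to 50%.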

Compound 3, a percentage reported as inhibition, in the whole organism at one dose (the size of the read-out at that dose, not a potency): 39.7%
Beside the measured number, compound 3's estimate is 14.7 percentage points below it; low and high end bracket the measured number.
By their numbers in this assay, from the lowest: compound 2; then compounds 1 and 3 (each within the scatter of the next).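

In this assay the fall seen earlier does not continue along the series: a number 19.1 percentage points higher from compound 2 to compound 3 (beyond the scatter), which runs opposite to a number 17.5 percentage points lower from compound 1 to compound 2 (beyond the scatter). The 2-chlorophenyl and 4-chlorophenyl members cannot be told apart, with a number 1.6 percentage points higher from compound 1 to compound 3 (within the scatter), so among these three compounds only the 3-chlorophenyl group of compound 2 stands apart, and the read-out does not follow a steady trend as the chlorine changes place on the ring. Nothing on hand gives a reason for the low number of compound 2.

Still open, from the compounds shown here alone, is whether chlorine matters at all on this saturated chain carbon bound to a sulfur, a question that a plain benzyl, a 4-methoxybenzyl or the longer 2-phenylethyl group could address. Also open, going by these compounds, is whether the gap around compound 2 holds at other doses and times, as all three numbers stand at a single dose and a single time, and they say nothing of potency.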